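The compounds below may be only part of what the source reports. "The series", "measured", "known", "first", "only" and "open" are said of these compounds alone.

Of the compounds shown here, three built on one shared core have been tested in an ADME assay on RAW264.7 cells (Mus musculus) for cytotoxicity, read by MTT assay, with a stated time of 24 h, tested at 2.5 ug/mL; on this read-out lower numbers stand for a stronger effect and higher numbers for a weaker effect at the one concentration tested. Compound 1 `COc1ccc(CCC(=O)c2cccc(O)c2)c(OC)c1` gives 88.5% in this assay. Compound 2 `COc1ccc(OC)c(CCC(=O)c2cccc(O)c2)c1` gives 96.8%, and compound 3 `COc1ccc(C(=O)CCc2ccc(OC)cc2OC)c(O)c1` gives 96.2%. All three numbers are high, so none of these compounds shows a strong effect on the cells at the single concentration used, and the gaps between them stay within the usual scatter of repeated measurements. Compound 3 stands second highest of the three; its nearest neighbour is compound 2 and its furthest is compound 1, yet neither gap counts as a real difference.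

The step in question leads to compound 4 `COc1ccc(CCC(=O)c2ccc(OC)cc2O)cc1`, which has not yet been measured in this assay. It differs from compound 3 in one place: hydrogen in place of methoxy on an aromatic carbon. For the measured compounds named here, no step between two measured compounds is available as a guide. Going by the values given here, none of the measured compounds differs from another in only one place. The three measured values lie close together, and the expected step is small, a number 3.2 percentage points lower from compound 3 to compound 4 (within the scatter), with no clear direction beyond the scatter. Compound 4 is therefore estimated at 93%, with a range from 82% to 102%.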

Compound 4, a percentage reported as activity, at one concentration (the size of the read-out at that concentration, not a potency): 94.5%
Estimate against measurement, compound 4: 1.5 percentage points below; the range from low to high includes it.
By their numbers in this assay, from the lowest: compounds 1, 4, 3 and 2 (each within the scatter of the next).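

In this assay, for the compounds shown here, this is the only direct comparison here between two compounds that differ in one place: a number 1.7 percentage points lower from compound 3 to compound 4 (within the scatter), with hydrogen in place of methoxy on an aromatic carbon, ortho to a large group. On this carbon, then, the methoxy group, with its 2 heavy atoms and 1 hydrogen-bond acceptor, can give way to a hydrogen without the read-out moving beyond the scatter, and both compounds still show only a weak effect on the cells at the one concentration tested. No measurement of any property of these compounds bears on this result, so the data offer no explanation for it.

Going by these compounds, what remains open is whether another group on this same aromatic carbon, such as an amine, a carboxylic acid or a longer chain, would give a number in this assay that stands beyond the scatter from compound 3. Also open, on these data alone, is whether the same swap of methoxy for hydrogen would read the same way elsewhere on the shared core, or at any other concentration, and a single step at a single concentration cannot settle either question.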